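A few compounds are considered here, and "the series" means these few. Any claim that something is new, unique, unknown or untested is made for them only; others in the source may bear on it.

Among the compounds with values here, in a functional assay on THP-1 cells (Homo sapiens) for inhibition (a higher number here means a weaker inhibitor, a lower number a stronger inhibitor), compound 2 `C[C@H](NC(=O)C(=O)Nc1ccccc1C(C)(C)C)C(=O)N[C@@H](CC(=O)O)C(=O)COC(=O)c1c(Cl)cccc1Cl` gives 11800 nM, the highest of the three numbers measured so far. Its nearest neighbour is compound 3 `C[C@H](NC(=O)C(=O)Nc1cc(C(C)(C)C)ccc1C(C)(C)C)C(=O)N[C@@H](CC(=O)O)C(=O)COC(=O)c1c(Cl)cccc1Cl`, which gives 3130 nM; the step of a 3.8-fold lower number from compound 2 to compound 3 (0.58 log units; beyond the scatter) came from tert-butyl in place of hydrogen on an aromatic carbon. Further away stands compound 1 `C[C@H](NC(=O)C(=O)Nc1ccccc1)C(=O)N[C@@H](CC(=O)O)C(=O)COc1c(F)c(F)cc(F)c1F`, which gives 140 nM and differs from compound 2 in more than one place, so no single step can be read from that pair.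

Compound 4 `C[C@H](NC(=O)C(=O)Nc1ccccc1-c1ccccc1)C(=O)N[C@@H](CC(=O)O)C(=O)COC(=O)c1c(Cl)cccc1Cl` has not yet been measured. It differs from compound 2 in one place: phenyl in place of tert-butyl on an aromatic carbon. Within the data shown here, only the step from compound 2 to compound 3 bears on this, and only loosely, since that step added a second tert-butyl elsewhere on the ring rather than exchanging the one that compound 4 gives up. Both tert-butyl and phenyl are built of carbon only and sit on the same aromatic carbon, ortho to a large group, so the expected step of a 1.5-fold lower number from compound 2 to compound 4 (0.17 log units; within the scatter) is small and may well fall within the usual scatter. Compound 4 is therefore expected to give about 8000 nM in this assay, most likely between 2500 nM and 25000 nM.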

Compound 4, half-maximal inhibitory concentration: 4360 nM
Estimate against measurement, compound 4: 1.8-fold (0.26 log units) above; the range from low to high includes it.
By their numbers in this assay, from the lowest: compound 1; then compounds 3 and 4 (each within the scatter of the next); then compound 2.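

Exchanging tert-butyl for phenyl on this aromatic carbon gives (a 2.7-fold lower number from compound 2 to compound 4 (0.43 log units; beyond the scatter)) in this assay, so a lower number, meaning a stronger inhibitor, comes with a flat aromatic ring here as well as with the branched group's replacement being tolerated at all. Within the data shown here, until now the only readable change on this ring was the addition of a second tert-butyl elsewhere (a 3.8-fold lower number from compound 2 to compound 3 (0.58 log units; beyond the scatter)), which left the group at this position untouched; this is the first change made at the position itself, and it too lowers the number by a modest amount. Both groups are carbon only, with no hydrogen-bond donors or acceptors and no net charge, and nothing measured here explains why the number moves with this exchange.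

From the compounds shown here alone, whether a group holding nitrogen or oxygen, such as an amine or a methoxy group, or a smaller one such as methyl, would serve on this aromatic carbon remains open. Compound 1 carries only hydrogen here but differs from compound 2 in more than one place, so what the position gives with no group on it cannot be read.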